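The source may report more compounds than this note shows. Statements on the series, on what has been measured and on what is new or still open speak of the compounds shown alone.

Compound 1 `COc1ccc(-c2cc(/C=C/C(=O)c3ccc(N)cc3)[nH]n2)cc1` gives -24% in a functional assay on M14 cells (Homo sapiens) for cytotoxicity, read by sulforhodamine B assay, with a stated time of 48 h, tested at 10 uM (on this read-out higher numbers stand for a weaker effect at the one concentration tested and lower numbers for a stronger effect), the second highest of three numbers: compound 2 `COc1ccc(C(=O)/C=C/c2cc(-c3cc(OC)c(OC)c(OC)c3)n[nH]2)cc1` gives -44%, a lower number beyond the scatter, and compound 3 `COc1cc(-c2cc(/C=C/C(=O)c3ccc(F)c(F)c3)[nH]n2)cc(OC)c1OC` gives 3%, a higher number beyond the scatter. Compound 4 `COc1ccc(-c2cc(/C=C/C(=O)c3ccc(N)cc3)[nH]n2)cc1OC` differs from compound 1 by methoxy in place of hydrogen on an aromatic carbon, the new methoxy sitting ortho to a methoxy group and meta to a large group. Within the data shown here, the only measured step, a number 47 percentage points higher from compound 2 to compound 3 (beyond the scatter), changes the ring on the carbonyl carbon, not the ring carrying the new methoxy, so no step bears directly on this change. Compound 2, which carries three methoxy groups on that ring, does show a lower number than compound 1, but the two differ elsewhere as well. Compound 4 is therefore expected to give -32%, between -55% and -8%, a step of a number 8 percentage points lower from compound 1 to compound 4 (within the scatter) that may fall within the scatter.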

Compound 4, a percentage reported as activity, at one concentration (the size of the read-out at that concentration, not a potency): -42%
Beside the measured number, compound 4's estimate is 10 percentage points above it; the measured number falls inside the stated range.
By their numbers in this assay, from the lowest: compounds 2 and 4 (each within the scatter of the next); then compound 1; then compound 3.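

In this assay, methoxy in place of hydrogen, ortho to a methoxy group, gives a number 18 percentage points lower from compound 1 to compound 4 (beyond the scatter), and a lower number here stands for a stronger effect. Among these compounds, this is the first direct reading of a change on this ring, since the earlier step concerned the ring on the carbonyl carbon. Nothing available explains the shift. From the compounds shown here alone, whether a longer ethoxy group or a chlorine atom in this place would act alike remains open. So does whether this step would hold with a different ring on the carbonyl carbon.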